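A Single Aryl Exchange and Its Expected Clearance

A few compounds are considered here, and "the series" means these few. Any claim that something is new, unique, unknown or untested is made for them only; others in the source may bear on it.

Of the compounds shown here, two have so far been measured in an ADME assay (liver) for metabolic stability, with Liver microsome (Homo sapiens) as the target, using microsomes and NADPH, with a stated time of 30 min, tested at 1 uM; a higher number here means faster removal of the compound, a lower number slower removal. Compound 1 `Cn1cc(-c2cc(C(O)(C(F)(F)F)C(F)(F)F)cnc2N2CCN(S(=O)(=O)c3ccc(N)nc3)CC2)cn1` gives 19 mL.min-1.g-1, and compound 2 `Nc1ccc(S(=O)(=O)N2CCN(c3ncc(C(O)(C(F)(F)F)C(F)(F)F)cc3-c3ccccc3O)CC2)cn1` gives 22 mL.min-1.g-1. Among the compounds with values here, on these two numbers compound 1 stands together with compound 2: the one measured step, a 1.2-fold higher number from compound 1 to compound 2 (0.06 log units; within the scatter), lies within the scatter.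

Compound 3 `CS(=O)(=O)c1ccc(-c2cc(C(O)(C(F)(F)F)C(F)(F)F)cnc2N2CCN(S(=O)(=O)c3ccc(N)nc3)CC2)cc1` has not yet been measured. It differs from compound 1 in a single place: 4-(methylsulfonyl)phenyl in place of 1-methyl-1H-pyrazol-4-yl on an aromatic carbon. The measured step from compound 1 to compound 2 altered the same position, exchanging the same leaving group for a different aromatic ring, and it moved the number only within the scatter. Within the data shown here, that step is the only guide here, and the group entering in compound 3 appears in none of the measured compounds. On this basis no step beyond the scatter is expected for compound 3 in this assay, which means a 1.2-fold higher number from compound 1 to compound 3 (0.06 log units; within the scatter). Compound 3 is therefore estimated at 22 mL.min-1.g-1, with a range from 10 mL.min-1.g-1 to 48 mL.min-1.g-1.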

Compound 3, intrinsic clearance in microsomes: 32 mL.min-1.g-1
The estimate for compound 3 lay 1.5-fold (0.16 log units) below the measured number; measured number inside the range.
By their numbers in this assay, from the lowest: compounds 1, 2 and 3 (each within the scatter of the next).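

In this assay the 4-(methylsulfonyl)phenyl group gives a 1.7-fold higher number from compound 1 to compound 3 (0.23 log units; within the scatter) and a 1.5-fold higher number from compound 2 to compound 3 (0.16 log units; within the scatter) and so does not separate from either earlier group. This position on the shared core has now carried three different aromatic groups: a five-membered ring with 2 hetero atoms and two six-membered rings of carbon only, with no step beyond the scatter among them. The new group also brings 10 heavy atoms in place of the 6 of 1-methyl-1H-pyrazol-4-yl, showing that this larger count at this position need not come with a step beyond the scatter. Going by these compounds, whether a group without an aromatic ring, such as an amine or a short alkyl chain, would stay as close to these three compounds remains open. Nothing available here explains the numbers of these compounds.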